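Tail change on the shared core: compound 1 to compound 3

The source may hold more compounds than are shown below. What is called first, only, known or untested is meant among the compounds shown, and "the series" means these compounds.

Measured:
compound 1 `COC(=O)CCCNC(=O)CN1CN(c2ccccc2)C2(CCN(C(=O)c3ccc(C4CCCCC4)cc3)CC2)C1=O` — 2500 nM
compound 2 `CC(C)(C)c1ccc(C(=O)N2CCC3(CC2)C(=O)N(CC(=O)NCNS(C)(=O)=O)CN3c2ccccc2)cc1` — 3200 nM

In an assay on HEK293 cells for displacement of a labelled ligand from NPC1-like intracellular cholesterol transporter 1 (Homo sapiens) (on this read-out higher numbers stand for weaker inhibition and lower numbers for stronger inhibition), compound 1 gives 2500 nM and compound 2 gives 3200 nM. The two numbers lie within the scatter of each other, so they read as the same, and compound 1 is not set apart from compound 2.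

Compound 3 `NCCNC(=O)CN1CN(c2ccccc2)C2(CCN(C(=O)c3ccc(C4CCCCC4)cc3)CC2)C1=O` differs from compound 1 by amino in place of (methoxycarbonyl)methyl on a saturated chain carbon, two bonds along the chain from an amide-type nitrogen. For the measured compounds named here, no measured pair shows this change, so its size is not known from the data. In this assay a step beyond the scatter is not expected in either direction; the expected step is no change at the digits printed from compound 1 to compound 3 (within the scatter). The estimate for compound 3 is 2500 nM, with a range of 700 nM to 9000 nM.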

Compound 3, half-maximal inhibitory concentration: 3800 nM
Compound 3: middle estimate off by 1.5-fold (0.18 log units), on the low side; the measured number falls inside the stated range.
By their numbers in this assay, from the lowest: compounds 1, 2 and 3 (each within the scatter of the next).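

In this assay, amino in place of (methoxycarbonyl)methyl on a saturated chain carbon, two bonds along the chain from an amide-type nitrogen, gives a 1.5-fold higher number from compound 1 to compound 3 (0.18 log units; within the scatter). This position therefore accepts both tails on the shared core without a step beyond the scatter, a one-place comparison that compound 2 could not give. No available evidence bears on this result. Still open, going by these compounds, is whether a carboxylic acid at the chain end, or a longer chain ending in an amine, would move the number beyond the scatter.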